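A few compounds are considered here, and "the series" means these few. Any claim that something is new, unique, unknown or untested is made for them only; others in the source may bear on it.

Half-lives so far in an ADME assay on microsomes from liver (Mus musculus) for metabolic stability; on this read-out higher numbers stand for a longer-lived compound and lower numbers for a shorter-lived compound:

compound 1 `NS(=O)(=O)CC(=O)NCCSc1nonc1/C(=N/O)Nc1ccc(F)c(Br)c1`: 1.12 h
compound 2 `CS(=N)(=O)CC(=O)NCCSc1nonc1/C(=N/O)Nc1ccc(F)c(Br)c1`: 1.25 h
compound 3 `CS(=O)(=O)NCCSc1nonc1/C(=N/O)Nc1ccc(F)c(Br)c1`: not yet measured

Compound 2 stands level with compound 1 on these numbers, and this pair is all there is to place it against. The change to compound 3 is a group of 4 heavy atoms (1 carbon, 2 oxygen, 1 sulfur; no ring) in place of a group of 7 heavy atoms (3 carbon, 1 nitrogen, 2 oxygen, 1 sulfur; no ring), on an amine nitrogen and brings in methylsulfonyl.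

Among the measured compounds shown here, only one measured step bears on this: a 1.1-fold higher number from compound 1 to compound 2 (0.05 log units; within the scatter) and it stays within the scatter. That step exchanged a group on a saturated chain carbon bound to a carbonyl carbon. For the measured compounds named here, no measured step yet replaces the whole group on the amine nitrogen, so the evidence is thin. In this assay no step beyond the scatter is expected, and no direction can be argued. The estimated step is a 1.0-fold lower number from compound 2 to compound 3 (0.02 log units; within the scatter) and it should be read as no real change. Compound 3 is estimated at 1.2 h with an expected range from 0.6 h to 2.5 h and that range is kept wide.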

Compound 3, half-life: 0.29 h
Beside the measured number, compound 3's estimate is 4.1-fold (0.62 log units) above it, outside the stated range (below it).
By their numbers in this assay, from the lowest: compound 3; then compounds 1 and 2 (each within the scatter of the next).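

Working notes on the group on the amine nitrogen: in this assay this position responds to replacement of the whole group, with methylsulfonyl in place of the group of 7 heavy atoms giving a 4.3-fold lower number from compound 2 to compound 3 (0.63 log units; beyond the scatter) and methylsulfonyl in place of (sulfamoylmethyl)carbonyl giving a 3.9-fold lower number from compound 1 to compound 3 (0.59 log units; beyond the scatter), both modest and beyond the scatter. The earlier exchange on the saturated chain carbon bound to a carbonyl carbon gave only a 1.1-fold higher number from compound 1 to compound 2 (0.05 log units; within the scatter), within the scatter, so the half-life held through that change and shifted only once the whole group on the amine nitrogen was replaced. The data shown offer no measurement that explains the shorter half-life of compound 3.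

Compound 3 differs from compound 1 and compound 2 by losing the carbonyl and the saturated chain carbon together with the terminal sulfur group, so the compounds shown cannot say which of these parts carries the step. Acetyl or ethylsulfonyl on the same amine nitrogen would help separate these parts, and how either would read on this half-life remains open.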